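This account rests on a few compounds, and the source may have more. Where it says the series, first, only, none or still open, it means among the compounds named here.

Compound 2 `CNc1ncnc2c1c(-c1cc3ccccc3o1)cn2[C@@H]1O[C@H](CO)[C@@H](O)[C@H]1O` is a nucleoside-like molecule carrying a 1-benzofuran-2-yl group and a methylamino group on its shared core. In a functional assay on HeLa S3 cells (Homo sapiens) for antiproliferative activity, read by XTT assay, with a stated time of 72 h (a higher number here means a weaker inhibitor, a lower number a stronger inhibitor), compound 2 gives > 20000 nM, which is a limit and not a number. Compound 1 `CNc1ncnc2c1c(-c1ccccc1)cn2[C@@H]1O[C@H](CO)[C@@H](O)[C@H]1O` gives > 20000 nM, also a limit. Compound 3 `C#Cc1cn([C@@H]2O[C@H](CO)[C@@H](O)[C@H]2O)c2ncnc(NC)c12` gives > 20000 nM, again a limit. As far as these compounds go, the whole measured set therefore comes down to the limit of > 20000 nM in this assay, at which 3 of the 3 values shown sit, so the true position of compound 2 is unknown.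

Compound 4 `Cc1ncnc2c1c(-c1cc3ccccc3o1)cn2[C@@H]1O[C@H](CO)[C@@H](O)[C@H]1O` keeps the 1-benzofuran-2-yl group, but methyl takes the place of methylamino on an aromatic carbon next to the ring nitrogen: methyl in place of methylamino on an aromatic carbon. The measured steps offer little guidance. They are a step that the two limits leave unreadable from compound 1 to compound 2, a step that the two limits leave unreadable from compound 1 to compound 3 and a step that the two limits leave unreadable from compound 2 to compound 3. All of them change the other aromatic substituent, and none touches the methylamino group, so no measured size can be carried over to this change.

The expectation in this assay is therefore cautious: a step towards a stronger inhibitor is possible, but compound 4 may well stay at the limit. The expected change is an at least 2.0-fold lower number from compound 2 to compound 4 (0.30 log units; that floor lies within the scatter). The estimate for compound 4 is 10000 nM, with an expected range from 1500 nM to 20000 nM.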

Compound 4, half-maximal inhibitory concentration: > 20000 nM
Compound 4 was reported as a limit; the forecaster's own chance of this, stated with the estimate: 55%; middle value at least 2.0-fold (0.30 log units) from the limit.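

In this assay compound 4 gives > 20000 nM, which is a limit and not a number. Compound 2 also stands at a limit, so no size can be read for the change between compound 2 and compound 4. The compounds shown leave open how strongly each one acts and whether methyl or methylamino makes any difference, and the whole set shares one result: the limit of > 20000 nM in this assay, at which 4 of the 4 values shown sit.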